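Dihydrofolate reductase series: aryl swap from compound 1

The compounds below may be only part of what the source reports. "The series", "measured", "known", "first", "only" and "open" are said of these compounds alone.

Two compounds of the series carry a measured number in an assay on isolated protein for inhibition of Dihydrofolate reductase (Homo sapiens), read by spectrophotometry, using NADPH, with stated times of 5 s and 6 min, tested at 5 uM; on this read-out higher numbers stand for a stronger effect at the one concentration tested and lower numbers for a weaker effect. Compound 1 `NC1=NC2(CCSCC2)N(OCCCOc2cccc(Cl)c2Cl)C(N)=N1` gives 83.8% in this assay. Compound 2 `NC1=NC2(CCOCC2)N(OCCCOc2ccccc2Cl)C(N)=N1` gives 83.3% in this assay. The two numbers sit within the usual scatter of each other, so no order between compound 1 and compound 2 can be read from them; compound 1 is taken as the starting point simply as the compound from which the next change is made. Going by the values given here, no step between measured compounds that differ in a single place is available, so the size of any step can only be a matter of expectation.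

Compound 3 `COc1ccc(OCCCON2C(N)=NC(N)=NC23CCSCC3)cc1` has not yet been measured in this assay. Its difference from compound 1 is 4-methoxyphenyl in place of 2,3-dichlorophenyl on an oxygen on a saturated carbon. Compound 1 and compound 2 both carry chlorine-bearing aryl groups, and nothing in the series shows what a 4-methoxyphenyl group does at this place. The expectation is a moderate decrease, likely just beyond the scatter, expressed as a number 15.8 percentage points lower from compound 1 to compound 3 (beyond the scatter). Compound 3 is accordingly estimated at 68%, with a range from 40% to 88%.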

Compound 3, a percentage reported as inhibition, at one concentration (the size of the read-out at that concentration, not a potency): 81.3%
Beside the measured number, compound 3's estimate is 13.3 percentage points below it; the range from low to high includes it.
By their numbers in this assay, from the lowest: compounds 3, 2 and 1 (each within the scatter of the next).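

In this assay, 4-methoxyphenyl in place of 2,3-dichlorophenyl on an oxygen on a saturated carbon gives a number 2.5 percentage points lower from compound 1 to compound 3 (within the scatter). This is the only step shown in which a single place changes, and it shows that this read-out, taken at one concentration, does not separate the two aryl groups: one with two chlorine atoms and one with a methoxy group and no chlorine. Chlorine on the aryl group is therefore not required for compound 3 to reach a number of this size, which the earlier compounds, both chlorine-bearing, could not show, and no available data bear on why the exchange leaves the read-out within the scatter.

As far as these compounds go, the read-out is the size of the effect at one concentration, not a potency, so any difference in potency between compound 1 and compound 3 remains open. Also open, from the compounds shown here alone, is how far this tolerance extends at this place, for example to a carboxylic acid or an amine on the phenyl ring, or to a longer chain between the ring oxygen and the core.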